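Moving a Trifluoromethyl Group on the Hydrazone Aryl

The compounds below may be only part of what the source reports. "The series", "measured", "known", "first", "only" and "open" are said of these compounds alone.

Compound 1 `CN(C(=O)NC(=O)c1cccc(C(F)(F)F)c1)c1nc(C(F)(F)F)c(C(=O)N/N=C/c2ccccc2C(F)(F)F)s1` gives 10.4 ug/mL in a functional assay on HepG2 cells (Homo sapiens) for inhibition, read by MTT assay, with a stated time of 72 h (on this read-out higher numbers stand for weaker inhibition and lower numbers for stronger inhibition), and stands level with compound 2 at the digits shown. Compound 2 `CN(C(=O)NC(=O)c1ccc(F)c(F)c1)c1nc(C(F)(F)F)c(C(=O)N/N=C/c2ccccc2C(F)(F)F)s1` gives 10.4 ug/mL in this assay, and no change at the digits printed from compound 1 to compound 2 (within the scatter). That step alters the aryl on the carbonyl carbon, not the hydrazone aryl. Compound 3 `CN(C(=O)NC(=O)c1cccc(C(F)(F)F)c1)c1nc(C(F)(F)F)c(C(=O)N/N=C/c2cccc(C(F)(F)F)c2)s1` differs from compound 1 by 3-(trifluoromethyl)phenyl in place of 2-(trifluoromethyl)phenyl on a carbon with a double bond to nitrogen. Among the measured compounds shown here, no measured step touches this position, so nothing measured bears on it directly. The step of no change at the digits printed from compound 1 to compound 3 (within the scatter) is therefore expected to stay within the scatter. Compound 3 is estimated at 10.4 ug/mL, with a range from 4.5 ug/mL to 24 ug/mL.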

Compound 3, half-maximal inhibitory concentration: 5.79 ug/mL
The estimate for compound 3 lay 1.8-fold (0.25 log units) above the measured number; the measured number falls inside the stated range.
By their numbers in this assay, from the lowest: compounds 3, 1 and 2 (each within the scatter of the next).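

Among the compounds shown here, this is the only measured step at the hydrazone aryl: in this assay, 3-(trifluoromethyl)phenyl in place of 2-(trifluoromethyl)phenyl on a carbon with a double bond to nitrogen gives a 1.8-fold lower number from compound 1 to compound 3 (0.25 log units; within the scatter). The two placements of the trifluoromethyl group therefore cannot be told apart on this read-out. Nothing available bears on the reason for this result. Still open, as far as these compounds go, is whether an amine or a carboxylic acid in place of the trifluoromethyl group on this aryl would shift the number beyond the scatter.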